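Removing a tert-butoxycarbonyl group in two series

The source may hold more compounds than are shown below. What is called first, only, known or untested is meant among the compounds shown, and "the series" means these compounds.

Compound 1 `C[C@H](NC(=O)c1cc(Cl)ccc1OCCNC(=O)OC(C)(C)C)C(=O)Nc1ccc([N+](=O)[O-])cc1Cl` carries a tert-butoxycarbonyl group on an amine nitrogen. In a functional assay on MCF7 cells (Homo sapiens) for inhibition, read by MTT assay, with a stated time of 72 h (a higher number here means a weaker inhibitor, a lower number a stronger inhibitor), compound 1 gives only a limit, > 10000 nM. Compound 2 `C[C@H](NC(=O)c1cc(Cl)ccc1OCCN)C(=O)Nc1ccc([N+](=O)[O-])cc1Cl` differs from it by hydrogen in place of tert-butoxycarbonyl on an amine nitrogen. In this assay compound 2 likewise gives only a limit, > 10000 nM. The step that the two limits leave unreadable from compound 1 to compound 2 therefore has no readable size because of the limit of > 10000 nM in this assay, at which 2 of the 3 values shown sit. Compound 3 `CC(C)(C)OC(=O)NCCOc1ccc(Cl)cc1C(=O)NCC(=O)Nc1ccc2c(c1)S(=O)(=O)C=C2` is built on another core; how the two cores differ is not broken down here. In this assay compound 3 gives 1430 nM. Compound 4 `NCCOc1ccc(Cl)cc1C(=O)NCC(=O)Nc1ccc2c(c1)S(=O)(=O)C=C2` differs from compound 3 by hydrogen in place of tert-butoxycarbonyl on an amine nitrogen, the same change at the same kind of place. Going by the values given here, compound 4 is expected to move only modestly from compound 3, a step of a 2.1-fold higher number from compound 3 to compound 4 (0.32 log units; beyond the scatter), since the one measured example, a step that the two limits leave unreadable from compound 1 to compound 2, offers no readable size to lean on. Compound 4 is thus estimated at 3000 nM, between 800 nM and 10000 nM.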

Compound 4, half-maximal inhibitory concentration: 9440 nM
Compound 4: middle estimate off by 3.1-fold (0.50 log units), on the low side; low and high end bracket the measured number.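

In this assay, hydrogen in place of tert-butoxycarbonyl on the amine nitrogen gives a 6.6-fold higher number from compound 3 to compound 4 (0.82 log units; beyond the scatter), so on this core the change goes with a weaker inhibitor. The same change on the core of compound 1 cannot be read, because compound 1 and compound 2 both give only a limit: the limit of > 10000 nM in this assay, at which 2 of the 4 values shown sit. The series therefore offers one sized step on one core, and it does not show whether that step carries over to the other core in size or even in direction.

The compounds shown leave open whether an acetyl or a methyl group on the same amine nitrogen would sit nearer to tert-butoxycarbonyl or to hydrogen. They also leave open what a longer chain in place of 2-aminoethyl would do.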